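Series notes: amide replacement on the shared core

The source may hold more compounds than are shown below. What is called first, only, known or untested is meant among the compounds shown, and "the series" means these compounds.

Among the compounds with values here, compound 1 `COc1ccc(CN(C(C)=O)c2cc(C)cc(C)c2)cc1` gives 2790 nM in an assay on HEK293 cells for displacement of a labelled ligand from Translocator protein (Homo sapiens), read by scintillation counting, with a stated time of 90 min (a higher number here means a weaker inhibitor, a lower number a stronger inhibitor), the second highest of the three numbers measured so far. Compound 2 `CC(=O)N(Cc1ccc(OCCF)cc1)c1cc(C)cc(C)c1` gives 3930 nM, and compound 3 `CC(=O)N(Cc1ccc(OCc2ccccc2)cc1)c1cc(C)cc(C)c1` gives 738 nM. The step of a 1.4-fold higher number from compound 1 to compound 2 (0.15 log units; within the scatter) stays within the scatter, whereas a 3.8-fold lower number from compound 1 to compound 3 (0.58 log units; beyond the scatter) and a 5.3-fold lower number from compound 2 to compound 3 (0.73 log units; beyond the scatter) are modest steps beyond it; all three alter only the group on the oxygen on the aromatic ring.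

Compound 4 `CCN(CC)C(=O)CN(Cc1ccc(OC)cc1)c1cc(C)cc(C)c1` differs from compound 1 in a different place: (diethylcarbamoyl)methyl in place of acetyl on a nitrogen on an aromatic ring. Within the data shown here, none of the measured steps touches this nitrogen, so no measured step bears directly on the change, and the expectation rests on the unchanged remainder of compound 1 alone. A shift of at most a modest size in this assay is therefore expected, with the direction uncertain, and the range kept wide. For compound 4 the estimate in this assay is 1500 nM, between 250 nM and 8000 nM. That estimate means an expected step of a 1.9-fold lower number from compound 1 to compound 4 (0.27 log units; within the scatter).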

Compound 4, inhibition constant: 4210 nM
Estimate against measurement, compound 4: 2.8-fold (0.45 log units) below; the range from low to high includes it.
By their numbers in this assay, from the lowest: compound 3; then compounds 1, 2 and 4 (each within the scatter of the next).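

In this assay, within the data shown here, a 1.5-fold higher number from compound 1 to compound 4 (0.18 log units; within the scatter) is the first measured step at the nitrogen on an aromatic ring, and it stays within the scatter. Acetyl, with 3 heavy atoms, and (diethylcarbamoyl)methyl, with 8, therefore cannot be told apart at this position with the rest of compound 1 unchanged, so the number here does not depend visibly on the size of this group across this one pair. Nothing available explains this outcome or bears on it.

Still open, from the compounds shown here alone, is how a group of another kind on this nitrogen would read, such as a chain ending in an amine or a carboxylic acid in place of acetyl. Also open, going by these compounds, is whether (diethylcarbamoyl)methyl would read the same on compound 3, whose oxygen carries the phenyl-bearing chain.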